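Compound 4: cyano in place of trifluoromethyl

This account rests on a few compounds, and the source may have more. Where it says the series, first, only, none or still open, it means among the compounds named here.

In an ADME assay on microsomes from liver (Mus musculus) for metabolic stability, read by LC-MS, using NADPH, with a stated time of 10 min, tested at 10 uM (on this read-out lower numbers stand for a shorter-lived compound and higher numbers for a longer-lived compound), compound 2 `Nc1ncnc2c1c(Oc1cc(C(F)(F)F)ccn1)nn2C1CC1` gives > 2.41 h, which is a limit and not a number. Compound 4 `N#Cc1ccnc(Oc2nn(C3CC3)c3ncnc(N)c23)c1` differs from it by cyano in place of trifluoromethyl on an aromatic carbon. Going by the values given here, no measured step touches that place. Compound 3 `CO[C@H]1CC[C@H](n2nc(Oc3cc(C(F)(F)F)ccn3)c3c(N)ncnc32)CC1` gives 0.217 h. Its step, an at least 11-fold lower number from compound 2 to compound 3 (1.04 log units; beyond the scatter), lies on an aromatic nitrogen and bears only loosely on this change. Closer evidence comes from compound 1 `N#Cc1ccnc(Oc2nn(C3CCC3)c3ncnc(N)c23)c1`, which also holds cyano, with a different group on the aromatic nitrogen, and gives 0.4 h. On that value a lower number is expected in this assay, with an estimated at least 2.4-fold lower number from compound 2 to compound 4 (0.38 log units; beyond the scatter). For compound 4 the estimated value is 1 h, with an expected range of 0.35 h to 3 h.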

Compound 4, half-life: > 2.41 h
Compound 4 ended at the assay's limit; the forecaster's own chance of this, stated with the estimate: 15%; middle value at least 2.4-fold (0.38 log units) from the limit.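

In this assay compound 4 gives > 2.41 h, a limit and not a number, so with cyclopropyl on the aromatic nitrogen, cyano on this aromatic carbon still reaches the assay's limit. With cyano held, cyclopropyl in place of cyclobutyl gives an at least 6.0-fold higher number from compound 1 to compound 4 (0.77 log units; beyond the scatter), so the short half-life seen earlier with cyano does not follow from cyano alone. The step between compound 2 and compound 4 cannot be read because both values are limits: the limit of > 2.41 h in this assay, at which 2 of the 4 values shown sit.

Going by these compounds, how far trifluoromethyl and cyano differ beyond that limit remains open. So does the effect of an amine or a carboxylic acid on this aromatic carbon.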